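Phenyl to Pyridin-3-yl: An Estimate Before Measurement

This account rests on a few compounds, and the source may have more. Where it says the series, first, only, none or still open, it means among the compounds named here.

Of the compounds shown here, two with a shared core have so far been tested in a functional assay on SK-BR-3 cells (Homo sapiens) for cytotoxicity, read by resazurin assay, with a stated time of 72 h; on this read-out lower numbers stand for stronger inhibition and higher numbers for weaker inhibition. Compound 1 `S=C(NCc1cccnc1)SCCc1nnn[nH]1` gives > 100000 nM, which is a limit of the assay rather than a number; (the limit of > 100000 nM in this assay, at which 1 of the 2 values shown sits). Within the data shown here, compound 2 `S=C(NCc1cccnc1)SCCc1nnc(-c2ccccc2)o1` gives 580 nM in this assay, the only actual number recorded, so it stands alone among the values shown. Compound 3 `S=C(NCc1cccnc1)SCCc1nnc(-c2cccnc2)o1` has not yet been measured. It differs from compound 2 in one place: pyridin-3-yl in place of phenyl on an aromatic carbon. No step between two measured compounds is shown, so there is no precedent here for what exchanging a phenyl for a pyridin-3-yl group does to the read-out. Compound 3 is expected to stay close to compound 2, with the step of a 1.4-fold higher number from compound 2 to compound 3 (0.14 log units; within the scatter) expected to fall within the usual scatter. Compound 3 is estimated at 800 nM, with a range from 250 nM to 3000 nM.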

Compound 3, half-maximal inhibitory concentration: 800 nM
Estimate against measurement, compound 3: no gap at the digits printed; measured number inside the range.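

In this assay, this exchange gives a 1.4-fold higher number from compound 2 to compound 3 (0.14 log units; within the scatter), so the two compounds cannot be told apart on this read-out. At this carbon of the five-membered ring, then, a pyridin-3-yl ring, with its one ring nitrogen and one hydrogen-bond acceptor, serves as well as a phenyl ring in this assay. Nothing measured here gives a reason for this result.

Among these compounds, compound 1 gives > 100000 nM, which is a limit and not a number, so no step involving it can be read. Among the compounds shown here, with only two aromatic rings compared at this position, it remains open what a saturated ring such as cyclohexyl, or a phenyl ring carrying an amine or a carboxylic acid, would do to the read-out.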